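A few compounds are considered here, and "the series" means these few. Any claim that something is new, unique, unknown or untested is made for them only; others in the source may bear on it.

Three compounds that share one core were tested in a functional assay on Ehrlich cells (Mus musculus) for cytotoxicity, tested at 100 ug/mL; a lower number here means a weaker effect, a higher number a stronger effect of the compound at the concentration tested. Compound 1 `COc1cc(N2C(N)=C(C#N)C(/C=C/c3ccccc3)C3=C2CC(C)(C)CC3=O)cc(OC)c1OC` gives 40%. Compound 2 `COc1cc(N2C(N)=C(C#N)C(c3cccc([N+](=O)[O-])c3)C3=C2CC(C)(C)CC3=O)cc(OC)c1OC` gives 30%. Compound 3 `COc1cc(N2C(N)=C(C#N)C(c3ccccc3Cl)C3=C2CC(C)(C)CC3=O)cc(OC)c1OC` gives 20%. On the numbers shown, compound 3 stands lowest: its nearest neighbour is compound 2, within the scatter, while a number 20 percentage points lower from compound 1 to compound 3 (beyond the scatter) puts compound 1 beyond the scatter, though only modestly.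

Compound 4 `COc1cc(N2C(N)=C(C#N)C(c3cccs3)C3=C2CC(C)(C)CC3=O)cc(OC)c1OC` has not yet been measured. It differs from compound 3 in one place: thiophen-2-yl in place of 2-chlorophenyl on a saturated ring carbon.

All three measured steps change the group on that same saturated ring carbon, so all three bear on this step. a number 10 percentage points lower from compound 1 to compound 2 (within the scatter) stayed within the scatter, as did a number 10 percentage points lower from compound 2 to compound 3 (within the scatter), and only a number 20 percentage points lower from compound 1 to compound 3 (beyond the scatter) went beyond it, by a modest amount. Among the measured compounds shown here, no measured compound carries thiophen-2-yl, so nothing here points to a direction for this particular swap. The expectation is therefore a step in this assay of no more than the usual scatter, in either direction.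

Compound 4 is estimated to give 25%, with a range from 10% to 45%. That estimate means an expected step of a number 5 percentage points higher from compound 3 to compound 4 (within the scatter).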

Compound 4, a percentage reported as activity, at one concentration (the size of the read-out at that concentration, not a potency): 20%
For compound 4 the middle estimate is 5 percentage points above the measured one; the measured number falls inside the stated range.
By their numbers in this assay, from the lowest: compounds 3, 4, 2 and 1 (each within the scatter of the next, the first and the last beyond it).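

Placed on this saturated ring carbon in this assay, thiophen-2-yl, a five-membered aromatic ring with one hetero atom, reads the same as the six-membered 2-chlorophenyl ring, with no change at the digits printed from compound 3 to compound 4 (within the scatter) and one hydrogen-bond acceptor more in the group that enters. With a number 10 percentage points lower from compound 2 to compound 4 (within the scatter) as well, compound 2, compound 3 and compound 4 now all lie within the scatter of one another, so these three aromatic rings on this carbon cannot be told apart here, while a number 20 percentage points lower from compound 1 to compound 4 (beyond the scatter) gives 2-phenylethenyl a second modest separation, though compound 1 itself remains within the scatter of compound 2. Nothing at hand gives a reason for these numbers.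

On these data alone, whether this carbon tolerates only aromatic rings and 2-phenylethenyl remains open, since a carboxylic acid, an amine or a plain saturated chain such as butyl on this carbon could read quite differently. Also open, as far as these compounds go, is whether the separation of compound 1 would hold at other concentrations, since every number here comes from a single tested concentration and compound 1 differs modestly at best.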